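Amino in place of nitro on compound 3

The compounds below may be only part of what the source reports. "The series", "measured", "known", "first", "only" and "open" are said of these compounds alone.

In a functional assay on T47D cells (Homo sapiens) for antiproliferative activity, read by MTT assay, with a stated time of 72 h (on this read-out lower numbers stand for stronger inhibition and higher numbers for weaker inhibition), compound 1 `COc1cc(-c2nccn2-c2ccc3[nH]ccc3c2)cc(OC)c1OC` gives 2100 nM, while compound 2 `COc1cc(-c2nccn2-c2cccc(C)c2)cc(OC)c1OC` gives 29300 nM. Compound 3 `COc1ccc(C(=O)Oc2cc(OC)c(OC)c(OC)c2)cc1[N+](=O)[O-]` gives 29600 nM, which is within the scatter of compound 2 and beyond the scatter from compound 1, so those two compounds share the weak end of this small set.

Compound 4 `COc1ccc(C(=O)Oc2cc(OC)c(OC)c(OC)c2)cc1N` carries amino in place of nitro on an aromatic carbon, ortho to a methoxy group: amino in place of nitro on an aromatic carbon.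

Within the data shown here, no measured pair shows this change, so the expectation is loose. The expected step in this assay is a 4.9-fold lower number from compound 3 to compound 4 (0.69 log units; beyond the scatter), toward stronger inhibition and beyond the scatter. For compound 4 the estimate is 6000 nM, with an expected range from 1000 nM to 35000 nM.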

Compound 4, half-maximal inhibitory concentration: > 100000 nM
Compound 4 gave a limit, no number; the forecaster's own chance of this, stated with the estimate: 10%; middle value at least 16-fold (1.22 log units) from the limit.
By their numbers in this assay, from the lowest: compound 1; then compounds 2 and 3 (each within the scatter of the next). At a limit, above all of these: compound 4.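

In this assay, amino in place of nitro, ortho to a methoxy group, gives an at least 3.3-fold higher number from compound 3 to compound 4 (0.52 log units; beyond the scatter), toward weaker inhibition. As far as these compounds go, compound 4 gives > 100000 nM, which is a limit and not a number, so the full size of the step stays unknown: the limit of > 100000 nM in this assay, at which 1 of the 4 values shown sits. Of the two groups seen at this position, only nitro keeps a measurable number.

Open, from the compounds shown here alone, is whether a hydroxyl, a fluorine or an acetamide here would read closer to nitro or to amino. Open too, going by these compounds, is how an amide link in place of the ester would read with nitro kept.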